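The source may hold more compounds than are shown below. What is called first, only, known or untested is meant among the compounds shown, and "the series" means these compounds.

Measured compounds in hand:

compound 1 `CCCCc1cnc(C(CCCO)Cc2ccc(-c3ccccc3C(=O)O)cc2)[nH]1` — 1900 nM
compound 2 `O=C(O)c1ccccc1-c1ccc(CCc2ncc(CC3CCC3)[nH]2)cc1` — 588 nM
compound 3 `O=C(O)c1ccccc1-c1ccc(CCc2ncc(CC3CCCCC3)[nH]2)cc1` — 41 nM

In an in vitro functional assay on cells for agonist activity at Bombesin receptor subtype-3 (Homo sapiens), read by luminescence and calcium flux (a lower number here means that less compound is needed, a higher number that more compound is needed for the effect), compound 1 gives 1900 nM, compound 2 gives 588 nM and compound 3 gives 41 nM. Compound 3 thus stands lowest of the three numbers; its nearest neighbour is compound 2, and compound 1 lies furthest from it. Among the compounds with values here, the only one-place step within the measured set is a 14-fold lower number from compound 2 to compound 3 (1.16 log units; beyond the scatter), a large move from a smaller saturated ring to a larger one.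

Compound 4 `N#Cc1cccc(Cc2cnc(CCc3ccc(-c4ccccc4C(=O)O)cc3)[nH]2)c1` has not been measured. Against compound 3 the change is 3-cyanophenyl in place of cyclohexyl on a saturated chain carbon bound to an aromatic carbon. Within the data shown here, no measured step covers an exchange of a saturated ring for an aromatic ring carrying a nitrile, so the single step measured only indicates that the group on this chain carbon can shift the number strongly in either direction. The expectation for compound 4 is therefore a modest rise with wide uncertainty, a 2.9-fold higher number from compound 3 to compound 4 (0.47 log units; beyond the scatter), giving an estimated value of 120 nM in this assay, within 25 nM to 600 nM.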

Compound 4, half-maximal effective concentration: 812 nM
Compound 4: the middle estimate sits 6.8-fold (0.83 log units) below what was measured; the whole stated range lies below it.
By their numbers in this assay, from the lowest: compound 3; then compounds 2 and 4 (each within the scatter of the next); then compound 1.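

In this assay, the position on the saturated chain carbon bound to an aromatic carbon does not simply accept any six-membered ring: replacing cyclohexyl with 3-cyanophenyl gives a 20-fold higher number from compound 3 to compound 4 (1.30 log units; beyond the scatter), a large step. Against the cyclobutyl group, the same entry gives a 1.4-fold higher number from compound 2 to compound 4 (0.14 log units; within the scatter), so among the three groups at this place only cyclohexyl gives a low number. No measurement shown here accounts for the change.

Because 3-cyanophenyl differs from cyclohexyl in both its aromatic ring and its nitrile, these two changes cannot be separated without plain phenyl or 3-cyanocyclohexyl at this place. Also open, from the compounds shown here alone, is whether cycloheptyl or a longer alkyl chain would bring the number below that of compound 3 41 nM or raise it.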